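The source may report more compounds than this note shows. Statements on the series, on what has been measured and on what is new or still open speak of the compounds shown alone.

Of the compounds shown here, three built on one shared core have been measured in an assay on HEK293 cells for displacement of a labelled ligand from NPC1-like intracellular cholesterol transporter 1 (Homo sapiens); a higher number here means a weaker inhibitor, a lower number a stronger inhibitor. Compound 1 `CC(C)(C)c1ccc(C(=O)N2CCC3(CC2)C(=O)N(CC(=O)NCCN)CN3c2ccccc2)cc1` gives 7000 nM, and compound 2 `CC(C)(C)c1ccc(C(=O)N2CCC3(CC2)C(=O)N(CC(=O)N2CCC(O)CC2)CN3c2ccccc2)cc1` gives 4700 nM; these two lie close, as a 1.5-fold lower number from compound 1 to compound 2 (0.17 log units; within the scatter) shows. Compound 3 `CC(C)(C)c1ccc(C(=O)N2CCC3(CC2)C(=O)N(CC(=O)NCCCCO)CN3c2ccccc2)cc1` gives 19200 nM, the highest of the three numbers, standing beyond the scatter from both: a 2.7-fold higher number from compound 1 to compound 3 (0.44 log units; beyond the scatter) and a 4.1-fold higher number from compound 2 to compound 3 (0.61 log units; beyond the scatter).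

Compound 4 `CC(C)(C)c1ccc(C(=O)N2CCC3(CC2)C(=O)N(CC(=O)N2CCCC(O)C2)CN3c2ccccc2)cc1` differs from compound 3 in a single place: 3-hydroxypiperidin-1-yl in place of (4-hydroxybutyl)amino on a carbonyl carbon. The closest comparison is the step between compound 2 and compound 3, in which the (4-hydroxybutyl)amino group took the place of 4-hydroxypiperidin-1-yl and the number rose modestly. Within the data shown here, compound 4 moves back toward a ring, though with the hydroxy group on a different ring carbon, for which no measured pair exists. A modest drop in the number is therefore expected: a 3.0-fold lower number from compound 3 to compound 4 (0.47 log units; beyond the scatter) is the estimated step, and compound 4 is expected to give about 6500 nM, between 2500 nM and 15000 nM.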

Compound 4, half-maximal inhibitory concentration: 12200 nM
The estimate for compound 4 lay 1.9-fold (0.27 log units) below the measured number, within the range that was stated.
By their numbers in this assay, from the lowest: compounds 2, 1, 4 and 3 (each within the scatter of the next, the first and the last beyond it).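

Going from the open chain to a ring is not enough on its own to bring the number down on this carbonyl carbon: in this assay, the change from (4-hydroxybutyl)amino to 3-hydroxypiperidin-1-yl stays small (a 1.6-fold lower number from compound 3 to compound 4 (0.20 log units; within the scatter)). The ring's hydroxy position does show a difference, with 3-hydroxypiperidin-1-yl giving a modestly weaker result than 4-hydroxypiperidin-1-yl (a 2.6-fold higher number from compound 2 to compound 4 (0.41 log units; beyond the scatter)). The (2-aminoethyl)amino and 3-hydroxypiperidin-1-yl groups cannot be told apart (a 1.7-fold higher number from compound 1 to compound 4 (0.24 log units; within the scatter)), and no measurement at hand explains any of these steps.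

The compounds shown leave open how a piperidin-1-yl without a hydroxy group, or a morpholin-4-yl, would compare at this place. They also leave open whether a shorter chain, such as (2-hydroxyethyl)amino, would differ from (4-hydroxybutyl)amino.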